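Emax notes on the two aryloxymethyl analogues and a pyridyl variant

A few compounds are considered here, and "the series" means these few. Any claim that something is new, unique, unknown or untested is made for them only; others in the source may bear on it.

Compound 1 `O=C1c2cc(COc3ccccc3)nn2CCN1c1ccncc1` and compound 2 `Cc1ccc(OCc2cc3n(n2)CCN(c2ccc(F)cc2)C3=O)cc1` share a core and differ at more than one place, so only their two readings are compared. In a functional assay on HEK293 cells for positive allosteric modulation of metabotropic glutamate receptor 5 (Homo sapiens), read by calcium flux (a lower number here means a smaller maximal response, a higher number a larger maximal response), compound 1 gives 72%, while compound 2 gives 58%; compound 2 thus stands lowest of the two numbers, with compound 1 a larger response beyond the usual scatter.

Compound 3 `O=C1c2cc(COc3ccc(F)cn3)nn2CCN1c1ccc(F)cc1` is not yet measured. It differs from compound 2 in one place: 5-fluoropyridin-2-yl in place of 4-methylphenyl on an oxygen on a saturated carbon.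

Among the compounds with values here, no single-point step between measured compounds exists in this set, so there is no measured precedent for this change. The estimated step from compound 2 to compound 3 in this assay is expected to be small, a number 4 percentage points higher from compound 2 to compound 3 (within the scatter), and not beyond the scatter in either direction. For compound 3 the expected value in this assay is 62%, with a range from 45% to 80%.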

Compound 3, largest response reached (Emax), in percent of the reference or control that the assay uses: 52%
Estimate against measurement, compound 3: 10 percentage points above; measured number inside the range.
By their numbers in this assay, from the lowest: compounds 3 and 2 (each within the scatter of the next); then compound 1.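

This gives the series its first single-place step at this position: in this assay, 5-fluoropyridin-2-yl in place of 4-methylphenyl on an oxygen on a saturated carbon gives a number 6 percentage points lower from compound 2 to compound 3 (within the scatter), so the two readings cannot be told apart. For this one pair, then, the largest response stays within the scatter although the ring gains a hetero atom and a hydrogen-bond acceptor at an unchanged count of heavy atoms. No measurement shown here speaks to the reason for this outcome.

The step changes the ring nitrogen, the fluorine and the loss of methyl together, so plain pyridin-2-yl on the same oxygen would be needed to read them apart. Going by these compounds, whether the position accepts a non-aromatic group, such as cyclohexyl, or a ring carrying a carboxylic acid remains open.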